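From dimethylamino to cyano on an aromatic carbon

This account rests on a few compounds, and the source may have more. Where it says the series, first, only, none or still open, it means among the compounds named here.

Measured so far in a functional assay on KB cells (Homo sapiens) for inhibition, with a stated time of 72 h; a higher number here means a weaker inhibitor, a lower number a stronger inhibitor:
- compound 1 `COc1ccc(S(=O)(=O)N2CCc3cccc(-c4ccc(N(C)C)cc4)c32)cc1` gives 539 nM 
- compound 2 `COc1ccc(S(=O)(=O)N2CCc3cccc(-c4cc(OC)c(OC)c(OC)c4)c32)cc1` gives 3690 nM 
- compound 3 `COc1ccc(S(=O)(=O)N2CCc3cccc(-c4c(F)c(F)c(F)c(F)c4F)c32)cc1` gives 4040 nM 

Compound 1 has the lowest number of the three, and its gaps to compound 2 and compound 3 both lie beyond the scatter. Compound 4 `COc1ccc(S(=O)(=O)N2CCc3cccc(-c4ccc(C#N)cc4)c32)cc1` carries cyano in place of dimethylamino on an aromatic carbon, para to a large group (cyano in place of dimethylamino on an aromatic carbon). Among the measured compounds shown here, no measured pair isolates this change, so the expectation rests on compound 2 at 3690 nM and compound 3 at 4040 nM, neither of which carries dimethylamino. The expected step of a 3.5-fold higher number from compound 1 to compound 4 (0.55 log units; beyond the scatter) points towards a weaker inhibitor, beyond the scatter. Compound 4 is estimated at 1900 nM in this assay, with an expected range of 550 nM to 6000 nM for now.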

Compound 4, half-maximal inhibitory concentration: 31.1 nM
Compound 4: the middle estimate sits 61-fold (1.79 log units) above what was measured; measured number outside the range, below it.
By their numbers in this assay, from the lowest: compound 4; then compound 1; then compounds 2 and 3 (each within the scatter of the next).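

In this assay, among the compounds shown here, the swap of dimethylamino for cyano gives a 17-fold lower number from compound 1 to compound 4 (1.24 log units; beyond the scatter), the only single-place step so far. This position, para to a large group, therefore responds strongly to one substituent change, and dimethylamino is not needed for a low number on the shared core. No measurement at hand accounts for the step.

Going by these compounds, whether the gain belongs to cyano itself or to the loss of dimethylamino stays open. A carboxylic acid, an acetyl group or a single chlorine at this place would help to separate the two.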